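Nitro in Place of Methyl on a Benzoxaborole Chalcone

This account rests on a few compounds, and the source may have more. Where it says the series, first, only, none or still open, it means among the compounds named here.

Compound 1 `O=C(/C=C/c1ccc2c(c1)B(O)OC2)c1cccnc1`: in a toxicity assay on MCF-10A cells (Homo sapiens) for cytotoxicity, read by MTT assay, with a stated time of 48 h (a higher number here means a weaker inhibitor, a lower number a stronger inhibitor), compound 1 gives 34400 nM.
Compound 2 `O=C(/C=C/c1ccc2c(c1)B(O)OC2)c1ccc(I)cc1`: compound 2 gives only a limit of this assay, > 100000 nM.
Compound 3 `Cc1ccc(C(=O)/C=C/c2ccc3c(c2)B(O)OC3)cc1`: compound 3 gives 8300 nM.

Compound 3 stands with the lowest number among those reported; its nearest neighbour is compound 1, and the step of a 4.1-fold lower number from compound 1 to compound 3 (0.62 log units; beyond the scatter) lies beyond the scatter. The third value is only a limit (the limit of > 100000 nM in this assay, at which 1 of the 3 values shown sits).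

Compound 4 `O=C(/C=C/c1ccc2c(c1)B(O)OC2)c1ccc([N+](=O)[O-])cc1` differs from compound 3 by nitro in place of methyl on an aromatic carbon. Among the measured compounds shown here, two measured steps bear on it: both replace one group at the same place on the aryl ring of the ketone. The step of an at least 12-fold lower number from compound 2 to compound 3 (1.08 log units; beyond the scatter) shows that a methyl here gives a much lower number than an iodo, and an at least 2.9-fold higher number from compound 1 to compound 2 (0.46 log units; beyond the scatter) shows the iodo giving a higher number than pyridin-3-yl. For the measured compounds named here, a nitro group has not been measured, but the only change away from methyl at this position so far raised the number. Compound 4 is therefore expected to give a modestly higher number than compound 3, a step of a 2.4-fold higher number from compound 3 to compound 4 (0.38 log units; beyond the scatter), with an estimate of 20000 nM in this assay, between 6000 nM and 80000 nM.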

Compound 4, half-maximal inhibitory concentration: 17500 nM
Estimate against measurement, compound 4: 1.1-fold (0.06 log units) above, within the range that was stated.
By their numbers in this assay, from the lowest: compound 3; then compounds 4 and 1 (each within the scatter of the next). At a limit, above all of these: compound 2.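

In this assay, nitro in place of methyl gives a 2.1-fold higher number from compound 3 to compound 4 (0.32 log units; beyond the scatter), so a second change away from methyl at this position also raises the number, here only modestly. Nitro and iodo also part clearly at the same aromatic carbon, with an at least 5.7-fold lower number from compound 2 to compound 4 (0.75 log units; beyond the scatter), which shows that a raised number is not the same for every group replacing methyl. The number for compound 2 is a limit, so this last step gives only a lower bound on the gap: the limit of > 100000 nM in this assay, at which 1 of the 4 values shown sits.

The compounds shown carry only methyl, nitro and iodo at this position, so what an amine or a carboxylic acid would give there remains open. They also leave open whether the same order of these groups would hold with the group at another place on the ring.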